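Swapping methoxy for methyl on a non-cytotoxic thiosemicarbazide

This account rests on a few compounds, and the source may have more. Where it says the series, first, only, none or still open, it means among the compounds named here.

Compound 1 `COc1cccc(NC(=S)NNC(=O)c2ccncc2)c1` was tested in an ADME assay on MCF-10A cells (Homo sapiens) for cytotoxicity, read by WST assay, with a stated time of 48 h; a lower number here means a stronger inhibitor, a higher number a weaker inhibitor. In this assay compound 1 gives > 300000 nM, which is a limit of the assay rather than a number. Compound 2 `O=C(NNC(=S)Nc1ccc(Cl)cc1)c1ccncc1` gives > 300000 nM, also a limit. Both sit at the limit of > 300000 nM in this assay, at which 2 of the 2 values shown sit. Compound 3 `Cc1cccc(NC(=S)NNC(=O)c2ccncc2)c1` differs from compound 1 only by methyl in place of methoxy on an aromatic carbon. Among the measured compounds shown here, with no measured step to guide the size of this change, the expected step that the limit leaves unreadable from compound 1 to compound 3 is none beyond the scatter. Compound 3 is therefore estimated at 400000 nM, within 150000 nM to 1000000 nM, most likely again reported as a limit.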

Compound 3, half-maximal inhibitory concentration: > 300000 nM
Compound 3: only a limit was reported; the forecaster's own chance of this, stated with the estimate: 85%; the middle value is on the limit's open side.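

Compound 1 and compound 3 give no readable step in this assay, because each is reported only as a limit: the limit of > 300000 nM in this assay, at which 3 of the 3 values shown sit.

The compounds shown leave open what concentration of any of them would harm these cells, and whether methyl and methoxy differ at all.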